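The source may report more compounds than this note shows. Statements on the series, on what has been measured and on what is new or still open speak of the compounds shown alone.

Measured so far in a functional assay on OVCAR-4 cells (Homo sapiens) for antiproliferative activity, read by WST assay, with a stated time of 3 days; on this read-out lower numbers stand for stronger inhibition and higher numbers for weaker inhibition:

- compound 1 `O=c1cc(I)n([C@@H]2O[C@H](CO)[C@@H](O)[C@H]2O)c(=O)[nH]1`: > 50000 nM
- compound 2 `Nc1cc(=O)[nH]c(=O)n1[C@@H]1O[C@H](CO)[C@@H](O)[C@H]1O`: > 50000 nM
- compound 3 `CNc1cc(=O)[nH]c(=O)n1[C@@H]1O[C@H](CO)[C@@H](O)[C@H]1O`: > 50000 nM

None of these three entries is a number, and all sit at one limit: the limit of > 50000 nM in this assay, at which 3 of the 3 values shown sit. Compound 1 therefore stands at that limit, level with the other two on the numbers shown, and its true position remains unknown.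

The next compound is compound 4 `O=c1[nH]c(=O)n([C@@H]2O[C@H](CO)[C@@H](O)[C@H]2O)c(I)c1Br`, which keeps the iodo group of compound 1 and adds a bromo group. The change is bromo in place of hydrogen on an aromatic carbon, ortho to an iodo group: bromo in place of hydrogen on an aromatic carbon.

The measured steps offer little guidance. Neither a step that the two limits leave unreadable from compound 1 to compound 2 nor a step that the two limits leave unreadable from compound 1 to compound 3 has a readable size, and the same holds for a step that the two limits leave unreadable from compound 2 to compound 3. The first two replace the iodo group and the third alters the amino group, so none of them tests a bromo group at the new place.

Any expectation is therefore weak, and the most likely result is another limit. If a number appears, it is expected to lie on the stronger side of the limit of compound 1, though only modestly. The estimated change is an at least 1.2-fold lower number from compound 1 to compound 4 (0.09 log units; that floor lies within the scatter). For compound 4 the expected value is 40000 nM, with an estimated range of 8000 nM to 100000 nM.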

Compound 4, half-maximal inhibitory concentration: > 50000 nM
Compound 4 ended at the assay's limit; the forecaster's own chance of this, stated with the estimate: 65%; middle value at least 1.2-fold (0.09 log units) from the limit.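

Compound 4 gives only a limit in this assay, as compound 1 does, so no step between compound 1 and compound 4 can be read, and all the compounds now stand level at one limit: the limit of > 50000 nM in this assay, at which 4 of the 4 values shown sit.

The compounds shown leave open where the true value of each lies and whether any of these changes to the shared core alters the read-out.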